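Cytotoxicity in a benzyl series: dichloro to bromo

The source may report more compounds than this note shows. Statements on the series, on what has been measured and on what is new or still open speak of the compounds shown alone.

Measured so far:
Compound 1, `O=C1c2sccc2N(Cc2ccccc2Br)S(=O)(=O)N1Cc1ccccc1`: > 270000 nM
Compound 2, `N#Cc1cccc(CN2c3ccsc3C(=O)N(Cc3ccccc3)S2(=O)=O)c1`: > 305000 nM
Compound 3, `O=C1c2sccc2N(Cc2ccc(Cl)cc2Cl)S(=O)(=O)N1Cc1ccccc1`: 247000 nM

In an ADME assay on MT4 cells (Homo sapiens) for cytotoxicity, read by MTT assay, with a stated time of 4 days (a lower number here means that less compound is tolerated, a higher number that more compound is tolerated), compound 1 gives > 270000 nM, which is a limit of the assay and not a number. Compound 2 gives > 305000 nM, again a limit. Among the measured compounds shown here, compound 3 gives 247000 nM, the only true number among the three. Compound 1 reaches only a limit (the limit of > 270000 nM in this assay, at which 1 of the 3 values shown sits). Compound 2 likewise reaches only a limit (the limit of > 305000 nM in this assay, at which 1 of the 3 values shown sits). The step of an at least 1.0-fold lower number from compound 1 to compound 3 (0.03 log units; that floor lies within the scatter) and the step of an at least 1.2-fold lower number from compound 2 to compound 3 (0.09 log units; that floor lies within the scatter) both have floors that sit within the scatter, and the step that the two limits leave unreadable from compound 1 to compound 2 cannot be read at all. So compound 3 stands as a well-tolerated compound, with nothing to separate it from the other two.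

Compound 4, `O=C1c2sccc2N(Cc2ccc(Br)cc2)S(=O)(=O)N1Cc1ccccc1`, differs from compound 3 in one place: 4-bromophenyl in place of 2,4-dichlorophenyl on a saturated chain carbon bound to a sulfonamide nitrogen in a ring. The measured steps that bear on it, the step from compound 1 to compound 3 and the step from compound 2 to compound 3, show that swapping one halogenated benzyl group for another changed nothing beyond the scatter. No step beyond the scatter is therefore expected here, and compound 4 is estimated at 260000 nM, between 150000 nM and 400000 nM, an expected step of a 1.1-fold higher number from compound 3 to compound 4 (0.02 log units; within the scatter).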

Compound 4, half-maximal cytotoxic concentration: 6600 nM
Compound 4: middle estimate off by 39-fold (1.60 log units), on the high side; the whole stated range lies above it.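

At this place, on a saturated chain carbon bound to a sulfonamide nitrogen in a ring, the choice of substituted phenyl group can matter greatly: in this assay, 4-bromophenyl in place of 2,4-dichlorophenyl gives a 37-fold lower number from compound 3 to compound 4 (1.57 log units; beyond the scatter). Even with bromine kept, 4-bromophenyl and 2-bromophenyl are far apart, with an at least 40-fold lower number from compound 1 to compound 4 (1.61 log units; beyond the scatter), and the gap from 3-cyanophenyl is just as clear, with an at least 46-fold lower number from compound 2 to compound 4 (1.66 log units; beyond the scatter). These last two steps are floors, since compound 1 and compound 2 each stand at a limit of the assay and not at a number.

Going by these compounds, what makes 4-bromophenyl stand apart remains open. A 4-chlorophenyl or 4-methylphenyl group in the same place would show whether bromine itself is needed or whether another group named in the same way behaves alike.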